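The compounds below may be only part of what the source reports. "The series", "measured", "known", "first", "only" and "open" are said of these compounds alone.

Working notes on the series.

Compound 3 `Nc1ccc(C(=O)/C=C/c2ccc3c(c2)B(O)OC3)cc1` gives 25400 nM in a toxicity assay on WI-38 cells (Homo sapiens) for cytotoxicity, read by MTT assay, with a stated time of 48 h (a higher number here means a weaker inhibitor, a lower number a stronger inhibitor), the lowest of the two numbers in hand. Its nearest neighbour is compound 1 `O=C(/C=C/c1ccc2c(c1)B(O)OC2)c1ccc(Br)cc1`, which gives 36700 nM in this assay; the step of a 1.4-fold lower number from compound 1 to compound 3 (0.16 log units; within the scatter) lies within the scatter. Compound 2 `O=C(/C=C/c1ccc2c(c1)B(O)OC2)c1ccc(O)cc1` reaches only the limit > 100000 nM in this assay, and the same limit is noted as the limit of > 100000 nM in this assay, at which 1 of the 3 values shown sits.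

Compound 4 `O=C(/C=C/c1ccc2c(c1)B(O)OC2)c1ccccc1O` has not been measured. It differs from compound 3 by 2-hydroxyphenyl in place of 4-aminophenyl on a carbonyl carbon. Among the compounds with values here, the steps that bear on it are an at least 3.9-fold lower number from compound 2 to compound 3 (0.59 log units; beyond the scatter) and an at least 2.7-fold higher number from compound 1 to compound 2 (0.43 log units; beyond the scatter): both show a hydroxy on the aryl ring moving the number up relative to amino or bromo. In compound 4 the hydroxy sits on 2-hydroxyphenyl rather than where it sits in compound 2, so the carry-over is uncertain, but a higher number is the expectation. For compound 4 the estimated step is a 2.4-fold higher number from compound 3 to compound 4 (0.37 log units; beyond the scatter). Compound 4 is therefore expected at about 60000 nM, within 25000 nM to 150000 nM, with a real chance the assay reports only a limit.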

Compound 4, half-maximal inhibitory concentration: > 100000 nM
Compound 4 ended at the assay's limit; the forecaster's own chance of this, stated with the estimate: 35%; at least 1.6-fold (0.22 log units) between middle value and limit.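

With 2-hydroxyphenyl on the carbonyl carbon, the separation first seen with 4-hydroxyphenyl appears again, with an at least 3.9-fold higher number from compound 3 to compound 4 (0.59 log units; beyond the scatter) and with an at least 2.7-fold higher number from compound 1 to compound 4 (0.43 log units; beyond the scatter). In this assay, the two hydroxy compounds, compound 2 and compound 4, therefore both stand apart from compound 1 and compound 3, and each gives only a limit: the limit of > 100000 nM in this assay, at which 2 of the 4 values shown sit.

The step from compound 2 to compound 4 cannot be read, so no order can be given for the 2-hydroxyphenyl and 4-hydroxyphenyl groups. As far as these compounds go, the actual numbers for compound 2 and compound 4 remain open, as does whether a methoxy group or a carboxylic acid on the aryl ring would give a number like those of the hydroxy compounds or like those of compound 1 and compound 3.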